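This account rests on a few compounds, and the source may have more. Where it says the series, first, only, none or still open, it means among the compounds named here.

Compound 2, `Cc1ccc(S(=O)(=O)N(C)CCCN(C)C)cc1C#Cc1cc(Cl)ccc1OCC(=O)O`, gives 287 nM in an assay on CHO cells for displacement of a labelled ligand from prostaglandin D2 receptor 2 (Homo sapiens), read by scintillation counting (a higher number here means a weaker inhibitor, a lower number a stronger inhibitor), the highest of the two numbers in this assay; its nearest neighbour is compound 1, `COCCN(C)S(=O)(=O)c1ccc(C)c(C#Cc2cc(Cl)ccc2OCC(=O)O)c1`, which gives 4.1 nM. Among the compounds with values here, the single measured step, a 70-fold higher number from compound 1 to compound 2 (1.85 log units; beyond the scatter), replaced methoxy with a (dimethylamino)methyl group and was large. Within the data shown here, compound 3, `Cc1ccc(S(=O)(=O)N(C)CCN(C)C)cc1C#Cc1cc(Cl)ccc1OCC(=O)O`, differs from compound 2 by dimethylamino in place of (dimethylamino)methyl on a saturated chain carbon, two bonds along the chain from a sulfonamide nitrogen; no measured step shortens this chain, and the step from compound 1 to compound 2 concerns the group rather than its length, so compound 3 is expected to change only modestly, probably toward a lower number, as a 1.9-fold lower number from compound 2 to compound 3 (0.28 log units; within the scatter). The estimate for compound 3 is 150 nM, within 40 nM to 600 nM.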

Compound 3, inhibition constant: 369 nM
The estimate for compound 3 lay 2.5-fold (0.39 log units) below the measured number; the measured number falls inside the stated range.
By their numbers in this assay, from the lowest: compound 1; then compounds 2 and 3 (each within the scatter of the next).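

Moving from (dimethylamino)methyl to dimethylamino on this saturated chain carbon gives a 1.3-fold higher number from compound 2 to compound 3 (0.11 log units; within the scatter) and so no readable change. Against methoxy, dimethylamino gives a 90-fold higher number from compound 1 to compound 3 (1.95 log units; beyond the scatter), so the large loss seen with compound 2 recurs in compound 3 and does not depend on that one chain length. Nothing given here accounts for this loss.

From the compounds shown here alone, it remains open whether a morpholine, a primary amine or a longer methoxy-ended chain at this place would fall near compound 1 or near compound 2 and compound 3. Going by these compounds, a carboxylic acid or an amide there is equally open.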